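From Methylamino to Ethylamino in an Antiproliferative Series

The compounds below may be only part of what the source reports. "The series", "measured", "known", "first", "only" and "open" are said of these compounds alone.

Measured so far in a functional assay on A549 cells (Homo sapiens) for antiproliferative activity, read by MTT assay, with a stated time of 48 h; on this read-out lower numbers stand for stronger inhibition and higher numbers for weaker inhibition:
- compound 1 `COc1ccc(C(=O)c2ccc(OC)c3c2OC(C)(C)C=C3)c(NC(=O)CO)c1`: 80 nM
- compound 2 `COc1ccc(C(=O)c2cc(OC)c(OC)c(OC)c2)c(NC(=O)CO)c1`: 70 nM
- compound 3 `CNCC(=O)Nc1cc(OC)ccc1C(=O)c1cc(OC)c(OC)c(OC)c1`: 610 nM

Among these three, compound 3 has the highest number, at 610 nM, so it shows the weakest inhibition of the set. The next compound to be tested is compound 4 `CCNCC(=O)Nc1cc(OC)ccc1C(=O)c1cc(OC)c(OC)c(OC)c1`. It differs from compound 3 by methyl in place of hydrogen on a saturated chain carbon bound to an amine nitrogen, which turns methylamino into ethylamino.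

Among the measured compounds shown here, one measured step bears on this change: an 8.7-fold higher number from compound 2 to compound 3 (0.94 log units; beyond the scatter), where methylamino replaced hydroxy. For the measured compounds named here, that was a different swap, and no measured pair shows methylamino going to ethylamino, so it is only a loose guide. A much smaller change than that step is expected here, leaning towards a slightly higher number in this assay. The expected step is a 1.3-fold higher number from compound 3 to compound 4 (0.12 log units; within the scatter), which may not rise beyond the usual scatter. For compound 4 the estimated value is 800 nM, with an expected range of 280 nM to 2300 nM.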

Compound 4, half-maximal inhibitory concentration: 750 nM
Beside the measured number, compound 4's estimate is 1.1-fold (0.03 log units) above it; low and high end bracket the measured number.
By their numbers in this assay, from the lowest: compounds 2 and 1 (each within the scatter of the next); then compounds 3 and 4 (each within the scatter of the next).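

In this assay, the added methyl on the saturated chain carbon bound to an amine nitrogen gives a 1.2-fold higher number from compound 3 to compound 4 (0.09 log units; within the scatter) and so leaves compound 3 and compound 4 within the usual scatter of each other. Replacing hydroxy with ethylamino gives an 11-fold higher number from compound 2 to compound 4 (1.03 log units; beyond the scatter) and, like the methylamino swap with an 8.7-fold higher number from compound 2 to compound 3 (0.94 log units; beyond the scatter) beside it, lies beyond the scatter, so at this position both amines shown give clearly higher numbers than the hydroxy group of compound 2. No measurement here explains why the hydroxy and amine compounds differ.

The compounds shown leave open whether a longer chain such as propylamino, or a plain amino or dimethylamino group, would stay with compound 3 and compound 4 or come closer to compound 2. They also leave open whether ethylamino would give a similar step on the core of compound 1.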